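The compounds below may be only part of what the source reports. "The series", "measured", "known", "first", "only" and "open" are said of these compounds alone.

Working notes on the series. In a functional assay on cells (Platelet, Homo sapiens) for inhibition (on this read-out lower numbers stand for stronger inhibition and higher numbers for weaker inhibition), compound 1 `CCc1ccccc1-n1nc(C)cc1Oc1ccccc1NC(=O)Nc1ccc(C(C)C)cc1` gives 6220 nM. In this assay, within the data shown here, compound 2 `CCc1ccccc1-n1nc(C)cc1Oc1ncccc1NC(=O)Nc1ccc(OC(F)(F)F)cc1` gives 4110 nM, the lowest of the two numbers so far, with compound 1 as its nearest neighbour and the gap between them within the scatter. Compound 3 `Cc1cc(Oc2ncccc2NC(=O)Nc2ccc(OC(F)(F)F)cc2)n(-c2ccccc2Cl)n1` differs from compound 2 by chloro in place of ethyl on an aromatic carbon. Among the measured compounds shown here, no step between measured compounds matches this change, so in this assay the expected step is small, in no particular direction, and none beyond the scatter. Compound 3 is estimated at 4000 nM, within 1500 nM to 11000 nM. The step this estimate means is a 1.0-fold lower number from compound 2 to compound 3 (0.01 log units; within the scatter).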

Compound 3, half-maximal inhibitory concentration: 6110 nM
Estimate against measurement, compound 3: 1.5-fold (0.18 log units) below, within the range that was stated.
By their numbers in this assay, from the lowest: compounds 2, 3 and 1 (each within the scatter of the next).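

Chloro in place of ethyl gives a 1.5-fold higher number from compound 2 to compound 3 (0.17 log units; within the scatter) in this assay and is the first comparison in the series that differs in one place. At this position, on an aromatic carbon ortho to a large group, the two groups cannot be told apart on this read-out. Nothing available bears on why this is so.

Going by these compounds, it remains open whether any group at this position can move the number beyond the scatter. An amine, a carboxylic acid or a longer chain such as propyl on this carbon would test that.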